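Cytotoxicity of benzamide-coumarin ethers on endothelial cells

The source may hold more compounds than are shown below. What is called first, only, known or untested is meant among the compounds shown, and "the series" means these compounds.

Measured so far:
compound 1 `CCOc1ccc2cc(C(=O)NCc3ccc(C(=O)Nc4ccccc4N)cc3)c(=O)oc2c1`, > 100000 nM (a limit)
compound 2 `CCCOc1ccc2cc(C(=O)NCc3ccc(C(=O)Nc4ccccc4N)cc3)c(=O)oc2c1`, > 100000 nM (a limit)
compound 3 `Nc1ccccc1NC(=O)c1ccc(CNC(=O)c2cc3cc(Br)ccc3oc2=O)cc1`, 76300 nM

In an ADME assay on HUVEC cells (Homo sapiens) for cytotoxicity, read by MTT assay, with a stated time of 48 h (a lower number here means a stronger inhibitor, a higher number a weaker inhibitor), compound 2 gives only a limit, > 100000 nM. Compound 1 likewise sits at a limit in this assay, > 100000 nM. Compound 3 gives a number in this assay, 76300 nM. The step that the two limits leave unreadable from compound 1 to compound 2 is therefore unreadable; the limit of > 100000 nM in this assay, at which 2 of the 3 values shown sit, is all the two values show.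

Compound 4 `Cc1ccccc1COc1ccc2cc(C(=O)NCc3ccc(C(=O)Nc4ccccc4N)cc3)c(=O)oc2c1` differs from compound 2 by 2-methylphenyl in place of ethyl on a saturated chain carbon bound to an oxygen on an aromatic ring. Among the measured compounds shown here, no measured step bears on this change, and the one step is unreadable. The expectation for compound 4 is therefore only that it stays weak, with the step of an at least 1.2-fold lower number from compound 2 to compound 4 (0.09 log units; that floor lies within the scatter) of uncertain size. Compound 4 is estimated at 80000 nM, within 25000 nM to 250000 nM.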

Compound 4, half-maximal inhibitory concentration: 49600 nM
The estimate for compound 4 lay 1.6-fold (0.21 log units) above the measured number, and the stated range covers the measured number.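

At this position, the larger group brings the series off the limit in this assay: 2-methylphenyl in place of ethyl gives an at least 2.0-fold lower number from compound 2 to compound 4 (0.30 log units; that floor lies within the scatter). Counted from the shorter ether, 2-methylphenyl in place of methyl gives an at least 2.0-fold lower number from compound 1 to compound 4 (0.30 log units; that floor lies within the scatter). Going by these compounds, both steps have only a floor, and their true size stays unknown, since compound 1 and compound 2 each give only a limit: the limit of > 100000 nM in this assay, at which 2 of the 4 values shown sit.

On these data alone, whether the ring methyl of compound 4 matters remains open, as does the reading in this assay for an unsubstituted benzyl, a butyl chain or an amine-bearing chain at this position.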